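Pyridin-4-yl replaces 1-methylpiperidin-4-yl on the carbonyl

A few compounds are considered here, and "the series" means these few. Any claim that something is new, unique, unknown or untested is made for them only; others in the source may bear on it.

In a physicochemical assay for solubility, at pH 7 (a higher number here means a more soluble compound, a lower number a less soluble compound), compound 1 (`CC(C)(C)C(=O)N1Cc2c(NC(=O)C3CCNCC3)n[nH]c2C1(C)C`) gives > 225000 nM, which is a limit of the assay and not a number. Compound 2 (`CN1CCC(C(=O)Nc2n[nH]c3c2CN(C(=O)C(C)(C)C)C3(C)C)CC1`) gives > 225000 nM, which is likewise only a limit. Compound 3 (`CC(C)(C)C(=O)N1Cc2c(NC(=O)c3ccncc3)n[nH]c2C1(C)C`) carries pyridin-4-yl in place of 1-methylpiperidin-4-yl on a carbonyl carbon. For the measured compounds named here, the one measured step is a step that the two limits leave unreadable from compound 1 to compound 2, so it sets no size for this change. A moderate downward move is therefore only a cautious expectation, and the expected step is an at least 1.8-fold lower number from compound 2 to compound 3 (0.27 log units; that floor lies within the scatter). For compound 3 the estimate is 120000 nM, with an expected range of 30000 nM to 225000 nM.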

Compound 3, solubility: 205000 nM
Estimate against measurement, compound 3: 1.7-fold (0.23 log units) below; measured number inside the range.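

For the compounds shown here, compound 3 gives the first real number in this assay, so a compound with an aromatic ring on this carbonyl carbon can be placed on the scale. Pyridin-4-yl in place of 1-methylpiperidin-4-yl gives an at least 1.0-fold lower number from compound 2 to compound 3 (0.04 log units; that floor lies within the scatter), and pyridin-4-yl in place of piperidin-4-yl gives an at least 1.0-fold lower number from compound 1 to compound 3 (0.04 log units; that floor lies within the scatter). Neither step has a true size, because compound 1 and compound 2 each sit at a limit: the limit of > 225000 nM in this assay, at which 2 of the 3 values shown sit.

Going by these compounds, how far compound 1 and compound 2 truly lie from compound 3 stays open. So does what a carboxylic acid, or a longer chain ending in an amine, would give on this carbonyl carbon.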